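Swapping a Thiazolidinedione for a Benzoate Ester

This account rests on a few compounds, and the source may have more. Where it says the series, first, only, none or still open, it means among the compounds named here.

Of the compounds shown here, three built on one shared core have been tested in an ADME assay on L02 cells (Homo sapiens) for cytotoxicity, read by MTT assay, with a stated time of 48 h; on this read-out lower numbers stand for stronger inhibition and higher numbers for weaker inhibition. Compound 1 `CN1CCN(C[C@H]2CN(c3ccc(-n4cc(-c5ccccn5)cn4)c(F)c3)C(=O)O2)CC1` gives 70 ug/mL. Compound 2 `O=C1O[C@@H](CN2CCC(O)CC2)CN1c1ccc(-n2cc(-c3ccccn3)cn2)c(F)c1` reaches only a limit of the assay, > 400 ug/mL. Compound 3 `O=C1CSC(=O)N1C[C@H]1CN(c2ccc(-n3cc(-c4ccccn4)cn3)c(F)c2)C(=O)O1` likewise reaches only a limit, > 400 ug/mL. On the numbers shown, compound 3 sits at the weak end of this assay, at the same limit as compound 2 (the limit of > 400 ug/mL in this assay, at which 2 of the 3 values shown sit), so its exact value is not known.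

Compound 4 `O=C(OC[C@H]1CN(c2ccc(-n3cc(-c4ccccn4)cn3)c(F)c2)C(=O)O1)c1ccccc1` differs from compound 3 in one place: benzoyloxy in place of 2,4-dioxo-1,3-thiazolidin-3-yl on a saturated chain carbon bound to a saturated ring carbon. For the measured compounds named here, two measured steps bear on this position. The step of an at least 5.7-fold higher number from compound 1 to compound 2 (0.75 log units; beyond the scatter) and the step of an at least 5.7-fold higher number from compound 1 to compound 3 (0.75 log units; beyond the scatter) both show that exchanging the 4-methylpiperazin-1-yl group of compound 1 for a different group at this place moved the number up to the limit. The step that the two limits leave unreadable from compound 2 to compound 3 cannot be read, since both of its values are limits. Going by the values given here, as every replacement seen at this place so far ends at the limit, a further replacement is expected to leave compound 4 near that limit, and the expected step of an at least 1.1-fold lower number from compound 3 to compound 4 (0.05 log units; that floor lies within the scatter) is none beyond the scatter. Compound 4 is therefore estimated at 350 ug/mL, with a range from 120 ug/mL to 400 ug/mL.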

Compound 4, half-maximal inhibitory concentration: > 400 ug/mL
Compound 4 ended at the assay's limit (the forecaster's own chance of this, stated with the estimate: 65%); at least 1.1-fold (0.05 log units) between middle value and limit.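

In this assay compound 4 gives > 400 ug/mL, which is a limit of the assay and not a number. Benzoyloxy is the first group at this place to contain no nitrogen, and it brings a six-membered aromatic ring of carbon only, yet replacing 4-methylpiperazin-1-yl with it still gives an at least 5.7-fold higher number from compound 1 to compound 4 (0.75 log units; beyond the scatter), so this shift is no longer seen only with nitrogen-containing replacements. The steps among compound 2, compound 3 and compound 4 cannot be read, so these three groups cannot be ranked, and the assay ceiling now dominates the series: the limit of > 400 ug/mL in this assay, at which 3 of the 4 values shown sit.

For the compounds shown here, how far compound 2, compound 3 and compound 4 really lie beyond that limit remains unknown, and compound 1 is still the only compound here with a measured number. A piperazin-1-yl group without the methyl, a piperidin-1-yl group or a morpholin-4-yl group at this place would help show which parts of the 4-methylpiperazin-1-yl group go with a value inside the measurable range.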